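Sulfonyl aryl swaps on a shared quinoline-like core

A few compounds are considered here, and "the series" means these few. Any claim that something is new, unique, unknown or untested is made for them only; others in the source may bear on it.

Three compounds share one core and differ only in the aryl group on the sulfonyl sulfur. Compound 1 `Cc1ccc(S(=O)(=O)c2cnc3ccc(F)cc3c2N2CCC(C)CC2)cc1C` gives 92% in an assay on isolated protein for displacement of a labelled ligand from metabotropic glutamate receptor 5 (Homo sapiens), with a stated time of 60 min, tested at 1 uM; on this read-out higher numbers stand for more inhibition at the one concentration tested (going by the name of the read-out) and lower numbers for less inhibition. Compound 2 `CC1CCN(c2c(S(=O)(=O)c3ccc(F)c(F)c3)cnc3ccc(F)cc23)CC1` gives 82%, and compound 3 `Cc1ccc(S(=O)(=O)c2cnc3ccc(F)cc3c2N2CCC(C)CC2)cc1F` gives 86%. Compound 3 holds the second of the three numbers, but both neighbours sit within the scatter: a number 4 percentage points higher from compound 2 to compound 3 (within the scatter), and a number 6 percentage points lower from compound 1 to compound 3 (within the scatter).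

Compound 4 `CC1CCN(c2c(S(=O)(=O)c3cccc(C#N)c3)cnc3ccc(F)cc23)CC1` is the next step from compound 3: 3-cyanophenyl in place of 3-fluoro-4-methylphenyl on a sulfonyl sulfur. Within the data shown here, the entering group brings a triple bond outside aromatic rings, which none of the measured compounds carry. Among the measured compounds shown here, the steps that bear on this position are a number 10 percentage points lower from compound 1 to compound 2 (within the scatter) and a number 6 percentage points lower from compound 1 to compound 3 (within the scatter); neither exceeded the scatter, so swaps of this aryl group have so far left the read-out essentially unchanged. For the measured compounds named here, no step shows a nitrile, so the expectation rests on that steadiness alone. Compound 4 is therefore expected to give about 80%, between 58% and 95%, which is an estimated step of a number 6 percentage points lower from compound 3 to compound 4 (within the scatter).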

Compound 4, a percentage reported as inhibition, at one concentration (the size of the read-out at that concentration, not a potency): 93%
Estimate against measurement, compound 4: 13 percentage points below; the range from low to high includes it.
By their numbers in this assay, from the lowest: compounds 2, 3, 1 and 4 (each within the scatter of the next, the first and the last beyond it).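

Among these compounds, the 3-cyanophenyl group is the first on the sulfonyl sulfur to bring a nitrile, and in this assay it leaves the number close to those of two earlier compounds, with a number 7 percentage points higher from compound 3 to compound 4 (within the scatter) and a number 1 percentage points higher from compound 1 to compound 4 (within the scatter). Among the compounds shown here, it also gives the first step at this position that clears the scatter, a number 11 percentage points higher from compound 2 to compound 4 (beyond the scatter), so the 3-cyanophenyl and 3,4-difluorophenyl groups can be told apart here, though only modestly. Nothing available accounts for that difference.

Going by these compounds, all four aryl groups give high numbers at a single concentration, so how their potencies compare remains open. Also open, on these data alone, is whether the number would hold with an amine or a carboxylic acid on the aromatic ring, or with a cyclohexyl group in place of the aryl group.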